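The source may report more compounds than this note shows. Statements on the series, on what has been measured and on what is new or still open speak of the compounds shown alone.

Compound 2 (`Nc1scc(CN2CCN(c3ccccc3F)CC2)c1C(=O)c1ccc(Cl)cc1`) is the starting point here. In a functional assay on CHO cells with adenosine receptor A1 (Homo sapiens) as the target, read by cAMP accumulation and immunoassay, with a stated time of 6 min, tested at 0.01 uM (on this read-out higher numbers stand for a weaker effect at the one concentration tested and lower numbers for a stronger effect), compound 2 gives 2.1%. Among the measured compounds shown here, the only other measured compound is compound 1 (`Nc1scc(CN2CCN(c3cccnc3)CC2)c1C(=O)c1ccc(Cl)cc1`), which in this assay gives 3.2%. The change from compound 1 to compound 2 replaces the pyridin-3-yl on the amine nitrogen of the ring with a 2-fluorophenyl, and the step of a number 1.1 percentage points lower from compound 1 to compound 2 (within the scatter) stays within the scatter, so the two compounds stand together on the numbers shown, both with small effects at the concentration tested.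

Compound 3 (`Nc1scc(CN2CCN(c3cc(F)ccc3F)CC2)c1C(=O)c1ccc(Cl)cc1`) has not yet been measured. It differs from compound 2 by fluoro in place of hydrogen on an aromatic carbon. For the measured compounds named here, the one measured step, a number 1.1 percentage points lower from compound 1 to compound 2 (within the scatter), exchanges the whole ring on the amine nitrogen rather than adding a fluoro to it, so it bears on this change only loosely; it was within the scatter. On that basis compound 3 is expected to show no step beyond the scatter, a number 0.4 percentage points higher from compound 2 to compound 3 (within the scatter). Compound 3 is therefore estimated at 2.5%, within a range from -6% to 12%.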

Compound 3, a percentage reported as activity, at one concentration (the size of the read-out at that concentration, not a potency): 3.1%
Beside the measured number, compound 3's estimate is 0.6 percentage points below it, within the range that was stated.
By their numbers in this assay, from the lowest: compounds 2, 3 and 1 (each within the scatter of the next).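

In this assay, putting a second fluoro on the aromatic ring, at the place meta to the large group and para to the existing fluoro, gives a number 1 percentage points higher from compound 2 to compound 3 (within the scatter) and so turns 2-fluorophenyl into 2,5-difluorophenyl with no step beyond the scatter. Among the compounds shown here, this is the first reading of a small addition to the ring itself, since the earlier step exchanged one whole ring for another. The exchange read against the pyridine compound, a number 0.1 percentage points lower from compound 1 to compound 3 (within the scatter), also stays inside the scatter, so on these numbers 2,5-difluorophenyl and pyridin-3-yl cannot be told apart, just as 2-fluorophenyl and pyridin-3-yl could not. Nothing available here speaks to the reason for this result.

From the compounds shown here alone, whether a larger group at this same place on the ring, such as a methoxy group or a carboxylic acid, would give a step beyond the scatter remains open. Going by these compounds, with all three compounds read at a single concentration, it also remains open how they would compare at other concentrations, where differences hidden here might appear.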